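Swapping a Methoxypyridine for a Benzyloxy Group

This account rests on a few compounds, and the source may have more. Where it says the series, first, only, none or still open, it means among the compounds named here.

Within the data shown here, compound 1 `COc1cc(OCc2cccc(-c3ccc(OC)nc3)c2)c2cc(-c3cn4nc(OC)sc4n3)oc2c1` is the one compound in this set with a plain number in hand. In an ADME assay on microsomes from liver (Homo sapiens) for metabolic stability (on this read-out higher numbers stand for a longer-lived compound and lower numbers for a shorter-lived compound), compound 1 gives 0.733 h. Compound 2 `COc1cc(OCc2csc(-c3ccc(C(=O)O)cc3)n2)c2cc(-c3cn4nc(OC)sc4n3)oc2c1` gives only a limit in this assay, > 2 h, so no exact number is known for it. Compound 1 therefore holds the only number shown, while the other value shown is a limit (the limit of > 2 h in this assay, at which 1 of the 2 values shown sits).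

The next compound, compound 3 `COc1cc(OCc2cccc(OCc3ccccc3)c2)c2cc(-c3cn4nc(OC)sc4n3)oc2c1`, differs from compound 1 in a single place: benzyloxy in place of 6-methoxypyridin-3-yl on an aromatic carbon. Among the measured compounds shown here, no pair of measured compounds here differs in just one spot, so there is no measured step of the same kind to lean on. With nothing of that sort to go by, the expectation is that the step from compound 1 to compound 3 stays close to the usual scatter, leaning slightly downward, which is written as a 1.2-fold lower number from compound 1 to compound 3 (0.09 log units; within the scatter). On that basis compound 3 is estimated to give 0.6 h in this assay, expected to fall somewhere between 0.3 h and 1.4 h, with only a small chance of reaching a limit as compound 2 did.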

Compound 3, half-life: 1.43 h
For compound 3 the middle estimate is 2.4-fold (0.38 log units) below the measured one, outside the stated range (above it).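

In this assay, among these compounds, the first step that can be read at this position is a 2.0-fold higher number from compound 1 to compound 3 (0.29 log units; within the scatter), so the two groups cannot be told apart on this read-out. On this aromatic carbon, meta to a large group, 6-methoxypyridin-3-yl can give way to benzyloxy, which has no ring nitrogen and fewer hydrogen-bond acceptors, without the half-life moving beyond what repeat measurements would show. Nothing shown here explains this result, and a single step cannot show whether it would hold on another core.

The compounds shown leave open how this position responds to a different kind of group, such as a primary amine on the same aromatic carbon or a longer ether chain carrying the benzene ring. Among the compounds shown here, compound 2 gives > 2 h in this assay, which is a limit of the assay, and it differs from the other two compounds in more than one place, so no step to it can be read.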